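Replacing a Nitrophenyl Group with Benzyl: An Estimate

The source may report more compounds than this note shows. Statements on the series, on what has been measured and on what is new or still open speak of the compounds shown alone.

Measured compounds:
compound 1, `CCOC(=O)c1cnc(-c2ccc(C(F)(F)F)cc2)nc1NN1C(=O)C=C(C)C1=O`, gives 400 nM in a functional assay on Jurkat cells for inhibition of nuclear factor NF-kappa-B complex (Homo sapiens); on this read-out higher numbers stand for weaker inhibition and lower numbers for stronger inhibition
compound 2, `CCOC(=O)c1cnc(-c2cccc([N+](=O)[O-])c2)nc1NN1C(=O)C=C(C)C1=O`, gives 7000 nM in this assay

For the measured compounds named here, compound 2 stands highest of the two numbers measured so far, that is, it is the weaker inhibitor. Going by the values given here, its nearest neighbour is compound 1, and the single measured step, an 18-fold higher number from compound 1 to compound 2 (1.24 log units; beyond the scatter), is large and lies beyond the usual scatter.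

Compound 3, `CCOC(=O)c1cnc(Cc2ccccc2)nc1NN1C(=O)C=C(C)C1=O`, differs from compound 2 in one place:
benzyl in place of 3-nitrophenyl on an aromatic carbon

Among the compounds with values here, only the step from compound 1 to compound 2 bears on this change, since it alters the same position of the shared core, and it shows that swapping the group there can move the number a great deal. Within the data shown here, no measured step, however, involves benzyl, so the direction of the change is uncertain. The step is therefore expected to be moderate in size and more likely downward, a 2.8-fold lower number from compound 2 to compound 3 (0.45 log units; beyond the scatter), with wide uncertainty. Compound 3 is estimated at 2500 nM, with a range from 400 nM to 15000 nM.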

Compound 3, half-maximal inhibitory concentration: 7000 nM
Estimate against measurement, compound 3: 2.8-fold (0.45 log units) below; low and high end bracket the measured number.
By their numbers in this assay, from the lowest: compound 1; then compounds 2 and 3 (each within the scatter of the next).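

In this assay, putting benzyl in place of 3-nitrophenyl gives no change at the digits printed from compound 2 to compound 3 (within the scatter), so these two groups cannot be told apart at this position, even though 3-nitrophenyl counts 2 hydrogen-bond acceptors and benzyl 0. Measured against 4-(trifluoromethyl)phenyl, benzyl gives an 18-fold higher number from compound 1 to compound 3 (1.24 log units; beyond the scatter), a step of the same size as the one to 3-nitrophenyl, so among these three compounds compound 1 alone stands apart as the stronger inhibitor, while the other two share one level. No measurement at hand explains this difference between compound 1 and the other two compounds.

On these data alone, it remains open whether the lower number of compound 1 belongs to the trifluoromethyl group itself or to its place on the phenyl ring, a question that plain phenyl or 3-(trifluoromethyl)phenyl at the same position could help settle. Also open, as far as these compounds go, is whether the same ranking of these groups would hold if a carboxylic acid or an amide stood in place of the ethoxycarbonyl group on the shared core.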